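Second trifluoromethyl on the aryl of compound 1

A few compounds are considered here, and "the series" means these few. Any claim that something is new, unique, unknown or untested is made for them only; others in the source may bear on it.

Compound 1 `O=C(Nc1cccc(-n2cc(-c3ccncc3)c(-c3ccc(Cl)c(O)c3)n2)c1)Nc1cccc(C(F)(F)F)c1` gives 1900 nM in a functional assay on NCI-H23 cells (Homo sapiens) for inhibition, read by sulforhodamine B assay, with a stated time of 48 h (a lower number here means a stronger inhibitor of growth, a higher number a weaker inhibitor of growth), the highest of the three numbers measured, though the others stand close. Compound 2 `COc1cc(-c2nn(-c3cccc(NC(=O)c4cccc(C(F)(F)F)c4)c3)cc2-c2ccncc2)ccc1Cl` gives 1560 nM in this assay, and compound 3 `O=C(Nc1cccc(-n2cc(-c3ccncc3)c(-c3ccc(Cl)c(O)c3)n2)c1)Nc1ccc(Cl)c(Cl)c1` gives 1220 nM; none of these numbers is separated from compound 1 by more than the usual scatter.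

The unmeasured compound 4 `O=C(Nc1cccc(-n2cc(-c3ccncc3)c(-c3ccc(Cl)c(O)c3)n2)c1)Nc1cc(C(F)(F)F)cc(C(F)(F)F)c1` differs from compound 1 by one change: trifluoromethyl in place of hydrogen on an aromatic carbon. The step that bears on it is the exchange of the aryl on the amide-type nitrogen, where a 1.6-fold lower number from compound 1 to compound 3 (0.19 log units; within the scatter) stayed within the scatter. Among the compounds with values here, that is the only guide, and it suggests that a change on the same aryl moves the number little. For compound 4 no step beyond the scatter is therefore expected in this assay, and the estimate a 1.3-fold lower number from compound 1 to compound 4 (0.10 log units; within the scatter) points at most slightly downward. Compound 4 is expected to give about 1500 nM, with a plausible range from 600 nM to 4000 nM.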

Compound 4, concentration for 50% growth inhibition: 1020 nM
Compound 4: middle estimate off by 1.5-fold (0.17 log units), on the high side, and the stated range covers the measured number.
By their numbers in this assay, from the lowest: compounds 4, 3, 2 and 1 (each within the scatter of the next).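

Adding a second trifluoromethyl, rather than exchanging one aryl for another, gives a 1.9-fold lower number from compound 1 to compound 4 (0.27 log units; within the scatter) in this assay. The earlier step showed only that replacing the whole aryl on the amide-type nitrogen left the number within the scatter. This step shows the same for a group of 4 heavy atoms entering on an aromatic carbon of that aryl, meta to a trifluoromethyl group.

The aryl groups shown on this nitrogen carry only trifluoromethyl or chlorine, so the effect of an amine or a carboxylic acid on this carbon in this assay remains open. Also open, as far as these compounds go, is whether a longer chain here would produce a step beyond the scatter. No measurement among the data shown bears on what lies behind this result.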